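A few compounds are considered here, and "the series" means these few. Any claim that something is new, unique, unknown or untested is made for them only; others in the source may bear on it.

Measured in a functional assay on A2780 cells (Homo sapiens) for inhibition, read by sulforhodamine B assay, with a stated time of 96 h; a higher number here means a weaker inhibitor of growth, a lower number a stronger inhibitor of growth:
- Compound 1 `CCC(O)[C@@H](CC)Nc1nc(NCc2ccccn2)c2ncn(C(C)C)c2n1`: 40000 nM
- Compound 2 `CC[C@@H](Nc1nc(NCc2ccccn2)c2ncn(C(C)C)c2n1)C(O)C(C)(C)C`: > 50000 nM, a limit of the assay
- Compound 3 `CC[C@H](Nc1nc(NCc2ccccn2)c2ncn(C(C)C)c2n1)C(C)O`: 17000 nM

Compound 3 has the lowest number of the three. The gap to its nearest neighbour is a 2.4-fold lower number from compound 1 to compound 3 (0.37 log units; beyond the scatter). The gap on the other side is an at least 2.9-fold lower number from compound 2 to compound 3 (0.46 log units; beyond the scatter), which rests on a limit, (the limit of > 50000 nM in this assay, at which 1 of the 3 values shown sits).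

Compound 4 `CCC(O)[C@H](CC)Nc1nc(NCc2ccccn2)c2ncn(C(C)C)c2n1` follows from compound 3 by one change, (methyl in place of hydrogen on a saturated chain carbon, two bonds along the chain from an oxygen on a saturated carbon). The 1-hydroxyethyl becomes 1-hydroxypropyl, with methyl in place of hydrogen two bonds along the chain from the oxygen. The closest measured evidence is a 2.4-fold lower number from compound 1 to compound 3 (0.37 log units; beyond the scatter), which exchanges the same two side chains in the opposite sense. It is not a clean guide, since compound 1 is drawn with the opposite configuration at the carbon on the nitrogen, while compound 3 and compound 4 share theirs. The further enlargement, an at least 1.2-fold higher number from compound 1 to compound 2 (0.09 log units; that floor lies within the scatter), also points only weakly towards a higher number. In this assay a small rise is therefore expected, no larger than the size seen in a 2.4-fold lower number from compound 1 to compound 3 (0.37 log units; beyond the scatter).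

The estimate corresponds to an expected 1.5-fold higher number from compound 3 to compound 4 (0.17 log units; within the scatter). For compound 4 the expected value is 25000 nM, with an estimated range from 10000 nM to 50000 nM.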

Compound 4, concentration for 50% growth inhibition: 23000 nM
Compound 4: middle estimate off by 1.1-fold (0.04 log units), on the high side, and the stated range covers the measured number.
By their numbers in this assay, from the lowest: compounds 3, 4 and 1 (each within the scatter of the next, the first and the last beyond it). At a limit, above all of these: compound 2.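

In this assay, the methyl that turns 1-hydroxyethyl into 1-hydroxypropyl gives a 1.4-fold higher number from compound 3 to compound 4 (0.13 log units; within the scatter), so with the configuration at the carbon on the nitrogen held the same, this change does not separate the two compounds; the earlier comparison of these side chains, compound 1 with compound 3, also carried a difference in that configuration. The pair that isolates the stereocentre gives a 1.7-fold lower number from compound 1 to compound 4 (0.24 log units; within the scatter), so inverting it does not move the number beyond the scatter either, although this reading carries a caveat: the fact that one of compounds 1 and 4 is drawn with a defined configuration and the other without, at the place where they differ Only the larger tert-butyl in place of ethyl gives a step beyond the scatter, an at least 2.1-fold lower number from compound 2 to compound 4 (0.33 log units; beyond the scatter), and the size of that step is only a floor, as compound 2 stands at a limit: the limit of > 50000 nM in this assay, at which 1 of the 4 values shown sits.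

The compounds shown leave open how the number responds when an amine or a methoxy group takes the place of the hydroxyl. They also leave open whether a phenyl group or a longer unbranched chain in place of the ethyl would behave like the ethyl or like the tert-butyl.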